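The source may hold more compounds than are shown below. What is called first, only, known or untested is meant among the compounds shown, and "the series" means these compounds.

Working notes on the series. In a functional assay on MG-63 cells (Homo sapiens) for inhibition, read by CCK-8 assay, with a stated time of 72 h, tested at 1 uM (a lower number here means less inhibition, a higher number more inhibition at the concentration tested (going by the name of the read-out)), compound 1, `CCN1C(=O)CSC1c1cccc(C(=O)NCCCCc2ccccc2)c1`, gives 0%, the lowest of the two numbers recorded so far. For the measured compounds named here, the other measured member, compound 2, `O=C(NCCCCc1ccccc1)c1cccc(C2OCC(=O)N2c2cccc(F)c2)c1`, gives 66% in this assay, a value well beyond the scatter above that of compound 1; no single-change step links the two, so their values are only set side by side here.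

The next step is from compound 1 to compound 3, `COc1ccc(N2C(=O)CSC2c2cccc(C(=O)NCCCCc3ccccc3)c2)c(OC)c1`, not yet measured in this assay. The change is 2,4-dimethoxyphenyl in place of ethyl on an amide-type nitrogen in a ring. Going by the values given here, compound 2 carries an aryl group on its ring amide-type nitrogen and gives 66%, which is the only hint available, since no measured step covers this exact change. Inhibition for compound 3 is therefore expected to rise, with an estimated step of a number 35 percentage points higher from compound 1 to compound 3 (beyond the scatter) beyond the scatter. Compound 3 is estimated at 35%, in a range from 5% to 70%.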

Compound 3, a percentage reported as inhibition, at one concentration (the size of the read-out at that concentration, not a potency): 56%
The estimate for compound 3 lay 21 percentage points below the measured number; the range from low to high includes it.
By their numbers in this assay, from the lowest: compound 1; then compounds 3 and 2 (each within the scatter of the next).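

In this assay, for the compounds shown here, the replacement of ethyl by 2,4-dimethoxyphenyl on the amide-type nitrogen in a ring gives a number 56 percentage points higher from compound 1 to compound 3 (beyond the scatter), the first single-place step. It shows that this one position alone can turn a compound with no recorded inhibition at the concentration tested into a clearly inhibiting one, with the rest of the core of compound 1 unchanged. No measurement offers an explanation for the size of this step.

The entering group adds both a six-membered aromatic ring and two methoxy groups, and this single step cannot separate their contributions. As far as these compounds go, whether a plain phenyl, a benzyl group or a longer alkyl chain such as n-butyl on this nitrogen would give a similar step remains open.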